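The source may hold more compounds than are shown below. What is called first, only, known or untested is meant among the compounds shown, and "the series" means these compounds.

Working notes on the series. For the measured compounds named here, in a functional assay on HT-29 cells (Homo sapiens) for cytotoxicity, read by MTT assay, with a stated time of 72 h (on this read-out higher numbers stand for weaker inhibition and lower numbers for stronger inhibition), compound 1 `CCOC(=O)c1sc2ccccc2c1Nc1cc(OC)c(OC)c(OC)c1` gives 1610 nM and compound 2 `COC(=O)c1sc2ccccc2c1Nc1cc(OC)c(OC)c(OC)c1` gives 299 nM, the lower of the two numbers so far. Compound 3 `COC(=O)c1sc2ccc(C)cc2c1Nc1cc(OC)c(OC)c(OC)c1` keeps the ester of compound 2 and changes the shared core: methyl in place of hydrogen on an aromatic carbon, with methyl in place of hydrogen on an aromatic carbon. Going by the values given here, only one measured step is available, a 5.4-fold lower number from compound 1 to compound 2 (0.73 log units; beyond the scatter), a modest step beyond the scatter. It lies at the ester chain, not at this ring, so it bears on the new change only indirectly: it shows that this assay can respond to a small alteration. Among the compounds with values here, no measured step fixes the direction here. A slightly higher number is expected, smaller than that ester step and probably within the scatter. The estimated change is a 1.3-fold higher number from compound 2 to compound 3 (0.13 log units; within the scatter). Compound 3 is expected at 400 nM, within an estimated range of 100 nM to 1400 nM.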

Compound 3, half-maximal inhibitory concentration: 299 nM
Estimate against measurement, compound 3: 1.3-fold (0.13 log units) above, within the range that was stated.
By their numbers in this assay, from the lowest: compounds 2 and 3 (each within the scatter of the next); then compound 1.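

In this assay the methyl in place of hydrogen gives no change at the digits printed from compound 2 to compound 3 (within the scatter), so one added methyl on this aromatic carbon, meta to a fused ring and para to a fused ring, leaves the read-out of the methyl ester series where compound 2 put it. For the compounds shown here, the earlier compounds showed only a change at the ester chain, a 5.4-fold lower number from compound 1 to compound 2 (0.73 log units; beyond the scatter), and this assay responded there, whereas the first change on the shared core shows no such response. No measurement in hand gives a reason for this result.

Going by these compounds, whether this carbon accepts more than a methyl stays open, since an amine, a carboxylic acid or a longer chain in the same place could behave differently. Whether a methyl on the other aromatic carbons of this ring would act the same also remains unsettled.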